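Selenium-to-sulfur swap on a fused two-ring core

A few compounds are considered here, and "the series" means these few. Any claim that something is new, unique, unknown or untested is made for them only; others in the source may bear on it.

Measured so far:
compound 1 `OCC#CCSc1cnc2ccccc2c1SCC#CCO`, 32 ug/mL
compound 2 `C#CCSc1cnc2ccccc2c1SCC#CCO`, 42.6 ug/mL
compound 3 `CSc1cnc2ccccc2c1[Se]CC#CCO`, 3.4 ug/mL

In a functional assay on SW707 cells (Homo sapiens) for cytotoxicity, read by sulforhodamine B assay, with a stated time of 72 h (a higher number here means a weaker inhibitor, a lower number a stronger inhibitor), compound 3 gives the lowest of the three numbers; compound 1 sits above it, and compound 2 sits furthest from it, both gaps beyond the scatter. Among the measured compounds shown here, the one measured step, a 1.3-fold higher number from compound 1 to compound 2 (0.12 log units; within the scatter), lies within the scatter and concerns a change on a triple-bonded carbon, not the change of interest here.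

Compound 4 `CSc1cnc2ccccc2c1SCC#CCO` differs from compound 3 in one place: a group of 6 heavy atoms (4 carbon, 1 oxygen, 1 sulfur; no ring) in place of a group of 6 heavy atoms (4 carbon, 1 oxygen, 1 selenium; no ring), on an aromatic carbon. For the measured compounds named here, no measured pair in this set isolates a selenium-for-sulfur exchange, so no step speaks to it directly. What the data do show is that compound 1 and compound 2, which carry only sulfur, both give much higher numbers than compound 3, which carries selenium. On that basis compound 4, now also carrying only sulfur, is expected to move toward the numbers of compound 1 and compound 2, so a step of a 5.9-fold higher number from compound 3 to compound 4 (0.77 log units; beyond the scatter) is expected, upward in this assay and beyond the scatter. The estimate for compound 4 in this assay is 20 ug/mL, in the range 6 ug/mL to 50 ug/mL.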

Compound 4, concentration for 50% inhibition: 34.9 ug/mL
The estimate for compound 4 lay 1.7-fold (0.24 log units) below the measured number; measured number inside the range.
By their numbers in this assay, from the lowest: compound 3; then compounds 1, 4 and 2 (each within the scatter of the next).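

In this assay, the selenium-bearing chain and the sulfur-bearing chain on this aromatic carbon, opposite the ring nitrogen, are now compared as a single change, and the step is large and beyond the scatter (a 10-fold higher number from compound 3 to compound 4 (1.01 log units; beyond the scatter)). The chain on the other sulfur shows no such sensitivity, since with the selenium position held as sulfur, hydrogen in place of ethynyl (a 1.2-fold lower number from compound 2 to compound 4 (0.09 log units; within the scatter)) and hydrogen in place of 3-hydroxyprop-1-yn-1-yl (a 1.1-fold higher number from compound 1 to compound 4 (0.04 log units; within the scatter)) both stay within the scatter, leaving these compounds indistinguishable. Within this set, then, the single atom linking the hydroxyl-ended chain to the aromatic carbon matters far more than the group on the neighbouring sulfur chain, although nothing given here explains the size of that step.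

Going by these compounds, what remains open is whether the selenium step would keep its size with a propargyl-type chain in place of the methylsulfanyl group, or with selenium placed at that other sulfur as well. On these data alone, it is also open how an oxygen or an amine nitrogen as the linking atom, or an amine or a carboxylic acid in place of the terminal hydroxyl, would read in this assay at this position.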